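Aryl exchange on compound 3: expected step

A few compounds are considered here, and "the series" means these few. Any claim that something is new, unique, unknown or untested is made for them only; others in the source may bear on it.

Values in a functional assay on KBVIN cells (Homo sapiens) for antiproliferative activity, read by sulforhodamine B assay, with a stated time of 3 days (a lower number here means that less compound is needed, a higher number that more compound is needed for the effect), are as follows.
- compound 1 `CCC1=C(O)c2c(oc(-c3cccc(C)c3)cc2=O)C(CC)(CC)C1=O` gives 3.69 uM
- compound 2 `CCC1=C(O)c2c(oc(-c3ccccc3OC)cc2=O)C(CC)(CC)C1=O` gives 3.26 uM
- compound 3 `CCC1=C(O)c2c(oc(-c3ccc(OC)c(F)c3)cc2=O)C(CC)(CC)C1=O` gives 0.1 uM

Compound 3 has the lowest number of the three, and its gaps to both others lie beyond the scatter. Compound 4 `CCC1=C(O)c2c(oc(-c3cc(C)c(O)c(C)c3)cc2=O)C(CC)(CC)C1=O` carries 4-hydroxy-3,5-dimethylphenyl in place of 3-fluoro-4-methoxyphenyl on an aromatic carbon. All measured steps change this same aryl group. Two large steps, a 37-fold lower number from compound 1 to compound 3 (1.57 log units; beyond the scatter) and a 33-fold lower number from compound 2 to compound 3 (1.51 log units; beyond the scatter), came with the arrival of 3-fluoro-4-methoxyphenyl, whereas a 1.1-fold lower number from compound 1 to compound 2 (0.05 log units; within the scatter) stayed within the scatter. Among the compounds with values here, no measured compound carries a hydroxy group on this aryl ring. The expected change, a rise beyond the scatter but smaller than those two large steps, is a 10-fold higher number from compound 3 to compound 4 (1.00 log units; beyond the scatter) in this assay as an estimate. For compound 4 the estimated value is 1 uM (range 0.25 uM to 4 uM).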

Compound 4, concentration for half-maximal effect: 8.9 uM
For compound 4 the middle estimate is 8.9-fold (0.95 log units) below the measured one; the whole stated range lies below it.
By their numbers in this assay, from the lowest: compound 3; then compounds 2 and 1 (each within the scatter of the next); then compound 4.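

In this assay, the aryl position on the shared core can also move the number upward: an 89-fold higher number from compound 3 to compound 4 (1.95 log units; beyond the scatter), and 4-hydroxy-3,5-dimethylphenyl also gives the highest number of the four, with a 2.7-fold higher number from compound 2 to compound 4 (0.44 log units; beyond the scatter) and a 2.4-fold higher number from compound 1 to compound 4 (0.38 log units; beyond the scatter). Within the data shown here, compound 4 is the only one here whose aryl group carries a hydrogen-bond donor. No supporting data bear on the cause of this rise. From the compounds shown here alone, the hydroxy group and the two methyl groups arrive together, so their separate contributions stay open. Also open, going by these compounds, is how 3-fluoro-4-hydroxyphenyl or an aryl ring bearing an amine would read.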